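Crotonamide series on the trimethoxyphenyl core: a benzyl swap

The source may report more compounds than this note shows. Statements on the series, on what has been measured and on what is new or still open speak of the compounds shown alone.

Compound 1 `C/C=C/C(=O)N(Cc1cccc(O)c1)c1cc(OC)c(OC)c(OC)c1` gives 14100 nM in a functional assay on MGC-803 cells (Homo sapiens) for inhibition, read by MTT assay, with a stated time of 48 h (a higher number here means a weaker inhibitor, a lower number a stronger inhibitor), the second highest of the three numbers recorded. For the measured compounds named here, compound 2 `COc1cc(NCc2cccc(O)c2)cc(OC)c1OC` gives 57600 nM, and the step of a 4.1-fold higher number from compound 1 to compound 2 (0.61 log units; beyond the scatter) is the only one-place change measured. Going by the values given here, compound 3 `COc1ccc(CN(C(=O)C=C(C)C)c2cc(OC)c(OC)c(OC)c2)cc1O` gives 320 nM, a far lower number, but it differs from compound 1 in two places, so no single step is drawn from it.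

Compound 4 `C/C=C/C(=O)N(Cc1ccc(OC)c(F)c1)c1cc(OC)c(OC)c(OC)c1` carries the change (3-fluoro-4-methoxyphenyl in place of 3-hydroxyphenyl on a saturated chain carbon bound to an amide-type nitrogen). Among the compounds with values here, no measured step touches this position, so the expectation rests loosely on the low number of compound 3, which also carries a methoxy on that ring. A modest downward step a 2.8-fold lower number from compound 1 to compound 4 (0.45 log units; beyond the scatter) is expected, with compound 4 estimated at 5000 nM, between 1500 nM and 20000 nM.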

Compound 4, half-maximal inhibitory concentration: 1650 nM
Compound 4: the middle estimate sits 3.0-fold (0.48 log units) above what was measured; the range from low to high includes it.
By their numbers in this assay, from the lowest: compound 3; then compound 4; then compound 1; then compound 2.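

For the compounds shown here, this is the first measured change at this place, on a saturated chain carbon bound to an amide-type nitrogen: in this assay the step is an 8.5-fold lower number from compound 1 to compound 4 (0.93 log units; beyond the scatter). With 3-fluoro-4-methoxyphenyl in place of 3-hydroxyphenyl, the group at this place has 0 hydrogen-bond donors and the number still falls, so the donor of 3-hydroxyphenyl is not needed for a number this low on the core of compound 1. Nothing available explains the step.

The fluorine and the methoxy enter together, so their separate shares remain unresolved. Also open, going by these compounds, is how an amine or a carboxylic acid on this ring would compare.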